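Moving the Methyl Group on a Pyridine Thiosemicarbazide

The source may report more compounds than this note shows. Statements on the series, on what has been measured and on what is new or still open speak of the compounds shown alone.

Compound 1 `Cc1cccc(/C(N)=N/NC(=S)N2CCN(c3ccccn3)CC2)n1`: 49.8%
Compound 2 `N/C(=N\NC(=S)N1CCOCC1)c1ccccn1`: 81.6%
Compound 3 `Cc1ccnc(/C(N)=N/NC(=S)N2CCOCC2)c1`: 12.8%

In a functional assay on MCF7 cells (Homo sapiens) for cytotoxicity, read by MTT assay, with a stated time of 72 h, tested at 100 uM (on this read-out higher numbers stand for more inhibition of growth at the one concentration tested and lower numbers for less inhibition of growth), compound 1 stands second of the three, beyond the scatter below compound 2 and beyond the scatter above compound 3. The unmeasured compound 4 `Cc1ccnc(/C(N)=N/NC(=S)N2CCN(c3ccccn3)CC2)c1` differs from compound 1 by 4-methylpyridin-2-yl in place of 6-methylpyridin-2-yl on a carbon with a double bond to nitrogen. Within the data shown here, no measured pair shows exactly this change, but the one step that bears on it, a number 68.8 percentage points lower from compound 2 to compound 3 (beyond the scatter), shows that a methyl group on the 4-methylpyridin-2-yl pattern goes with a much lower number than the unsubstituted ring. Compound 1 already carries a methyl group, so a smaller drop is expected in this assay, on the order of a number 19.8 percentage points lower from compound 1 to compound 4 (beyond the scatter). Compound 4 is therefore estimated at 30%, within a range from 5% to 60%.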

Compound 4, percent growth inhibition at one concentration: 63.4%
For compound 4 the middle estimate is 33.4 percentage points below the measured one; measured number outside the range, above it.
By their numbers in this assay, from the lowest: compound 3; then compound 1; then compound 4; then compound 2.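

Moving the methyl group, with the atoms otherwise unchanged, gives a number 13.6 percentage points higher from compound 1 to compound 4 (beyond the scatter) in this assay, so its place on the ring matters here. Compound 4 also keeps a fairly high number with 4-methylpyridin-2-yl, while compound 3, which carries the same group, gives 12.8% in this assay; this group alone therefore does not fix a low number. No measurement here explains the difference between compound 1 and compound 4. Going by these compounds, it remains open whether an amine or a methoxy group in place of the methyl group would keep this number.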